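Swapping the benzyl group on a carbamate

The source may hold more compounds than are shown below. What is called first, only, known or untested is meant among the compounds shown, and "the series" means these compounds.

Measured in a functional assay on RAW264.7 cells (Mus musculus) for inhibition, read by MTT assay, with a stated time of 72 h; on this read-out higher numbers stand for weaker inhibition and lower numbers for stronger inhibition:
- compound 1 `CCc1nc2c(C)cc(-c3ccc(CN4CCN(C)CC4)cc3)cn2c1NC(=O)OCc1cc(Cl)cc(Cl)c1`: 1410 nM
- compound 2 `CCc1nc2c(C)cc(-c3ccc(CN4CCN(C)CC4)cc3)cn2c1NC(=O)OCc1ccc(C(F)(F)F)cc1`: > 20000 nM (a limit of the assay, not a number)

Compound 2 stands at the limit of > 20000 nM in this assay, at which 1 of the 2 values shown sits, so it has only a limit and no exact value. Compound 3 `CCc1nc2c(C)cc(-c3ccc(CN4CCN(C)CC4)cc3)cn2c1NC(=O)OCc1ccc(F)c(F)c1` differs from it in a single group: 3,4-difluorophenyl in place of 4-(trifluoromethyl)phenyl on a saturated chain carbon bound to an oxygen next to a carbonyl group. The new 3,4-difluorophenyl sits on the same saturated chain carbon bound to an oxygen next to a carbonyl group.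

For the measured compounds named here, one measured step bears on this change, an at least 14-fold higher number from compound 1 to compound 2 (1.15 log units; beyond the scatter). It is large and concerns the same place, so the group there can strongly move the result. Compound 1, at 1410 nM, shows that a group at this place can give a measurable number. Going by the values given here, with only this one step as a guide, a lower number than the limit is expected in this assay, though compound 3 may still reach the limit. The expected change is an at least 2.8-fold lower number from compound 2 to compound 3 (0.45 log units; beyond the scatter). For compound 3 the estimated value is 7000 nM, with an expected range of 1800 nM to 20000 nM.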

Compound 3, half-maximal inhibitory concentration: 3590 nM
Compound 3: middle estimate off by 1.9-fold (0.29 log units), on the high side; the range from low to high includes it.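

In this assay, the 3,4-difluorophenyl group gives a measurable number again, an at least 5.5-fold lower number from compound 2 to compound 3 (0.74 log units; beyond the scatter), so compound 1 is no longer the only compound shown with a measurable number and a second halogen-bearing ring also works at this place. The two rings that give numbers are not interchangeable either, a 2.5-fold higher number from compound 1 to compound 3 (0.41 log units; beyond the scatter), which means the result responds to differences among measurable groups as well as to the gap between these groups and 4-(trifluoromethyl)phenyl. The first of these steps gives only a minimum size, because compound 2 carries a limit and not an exact number: the limit of > 20000 nM in this assay, at which 1 of the 3 values shown sits.

Compound 2 and compound 3 differ in both the kind of substituent and where it stands on the ring, so these compounds cannot show which of the two matters more. From the compounds shown here alone, it also remains open how this place would respond to a ring with no substituent, a ring with a single fluorine, or a ring carrying an amine or a carboxylic acid.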